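The source may hold more compounds than are shown below. What is called first, only, known or untested is meant among the compounds shown, and "the series" means these compounds.

Compound 2 `CSc1ccc(CCCCCCC(=O)c2ncc(-c3ccccn3)o2)cc1` gives the lowest of the two numbers recorded in an assay for inhibition of Fatty-acid amide hydrolase 1 (Rattus norvegicus) (on this read-out higher numbers stand for weaker inhibition and lower numbers for stronger inhibition), at 2.5 nM; its nearest neighbour, compound 1 `Nc1cccc(CCCCCCC(=O)c2ncc(-c3ccccn3)o2)c1`, gives 30 nM, and the step of a 12-fold lower number from compound 1 to compound 2 (1.08 log units; beyond the scatter) lies beyond the scatter. Compound 3 `O=C(CCCCCS(=O)(=O)c1ccccc1)c1ncc(-c2ccccn2)o1` differs from compound 2 by phenylsulfonyl in place of 4-(methylsulfanyl)benzyl on a saturated chain carbon, five bonds along the chain from a carbonyl carbon. For the measured compounds named here, only the step from compound 1 to compound 2 touches the same end of the molecule, and it was large, so changes there have moved the number before; yet the present change, with the whole benzyl leaving and a shorter phenylsulfonyl entering, is not covered by any measured pair. Compound 3 is therefore expected to give 40 nM, within 5 nM to 300 nM, a step of a 16-fold higher number from compound 2 to compound 3 (1.20 log units; beyond the scatter) toward weaker inhibition.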

Compound 3, inhibition constant: 6000 nM
Estimate against measurement, compound 3: 150-fold (2.18 log units) below; the measured number lies above the stated range.
By their numbers in this assay, from the lowest: compound 2; then compound 1; then compound 3.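

In this assay, phenylsulfonyl in place of 4-(methylsulfanyl)benzyl brings a 2400-fold higher number from compound 2 to compound 3 (3.38 log units; beyond the scatter) and phenylsulfonyl in place of 3-aminobenzyl brings a 200-fold higher number from compound 1 to compound 3 (2.30 log units; beyond the scatter) on this saturated chain carbon, five bonds along the chain from a carbonyl carbon. Both steps are larger than the earlier 12-fold lower number from compound 1 to compound 2 (1.08 log units; beyond the scatter) at this end of the molecule, so this position can move the number much further than that pair showed. No evidence accounts for the size of these steps. From the compounds shown here alone, what a benzylsulfonyl group or a longer chain ending in phenylsulfonyl would give at this place stays open.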